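This account rests on a few compounds, and the source may have more. Where it says the series, first, only, none or still open, it means among the compounds named here.

Compound 1 `COc1ccc(C(=O)/C(=C/c2ccccc2Cl)COC(=O)c2ccccc2)cc1` gives 7000 nM in a functional assay on NB-4 cells (Homo sapiens) for inhibition, read by XTT assay, with a stated time of 48 h (on this read-out higher numbers stand for weaker inhibition and lower numbers for stronger inhibition), the lowest of the two numbers shown; compound 2 `COc1ccc(C(=O)/C(=C/c2ccccc2Cl)CCOC(C)=O)cc1` gives 51600 nM in this assay, and the step of a 7.4-fold higher number from compound 1 to compound 2 (0.87 log units; beyond the scatter) accompanies acetoxymethyl in place of benzoyloxy on a saturated chain carbon bound to a double-bonded chain carbon. Compound 3 `COc1ccc(C(=O)/C(=C\c2ccccc2Cl)COC(=O)c2ccccc2)cc1` differs from compound 1 in that (the two compounds have the same atoms and bonds and differ only in configuration as drawn: 1 of 1 stereo elements differ; a double bond is drawn E in compound 1 and Z in compound 3). Among the measured compounds shown here, no measured step alters a double-bond configuration, so the single known step offers no direct guide, and the number for compound 3 is expected to change little, the expected step being a 1.3-fold higher number from compound 1 to compound 3 (0.11 log units; within the scatter). Compound 3 is estimated at 9000 nM, within a range from 3000 nM to 30000 nM.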

Compound 3, half-maximal inhibitory concentration: 18000 nM
Compound 3: middle estimate off by 2.0-fold (0.30 log units), on the low side; measured number inside the range.
By their numbers in this assay, from the lowest: compound 1; then compound 3; then compound 2.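

The configuration of the double bond counts at this position: in this assay there is a 2.6-fold higher number from compound 1 to compound 3 (0.41 log units; beyond the scatter), with E drawn in the first and Z in the second. Until now, only the ester on the chain had changed, and this step can be assigned to the double-bond configuration alone because nothing else separates the pair: the fact that compounds 1 and 3 differ only in the configuration as drawn.

Going by these compounds, whether the Z form would also read higher with the acetoxymethyl group of compound 2 remains open. So does how an amine or a carboxylic acid on that chain would read in either configuration.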